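The source may hold more compounds than are shown below. What is called first, only, known or untested is meant among the compounds shown, and "the series" means these compounds.

Compound 1 `CCC(=O)N1c2ccccc2CCC1C(=O)Nc1ccccc1C(F)(F)F` gives > 80000 nM (a limit)
Compound 2 `O=C(Nc1ccccc1C(F)(F)F)C1CCc2ccccc2N1C(=O)c1cccc(Cl)c1` gives 754 nM (a number)

In a functional assay on NUGC-3 cells (Homo sapiens) for cytotoxicity, read by sulforhodamine B assay, with a stated time of 72 h (on this read-out higher numbers stand for weaker inhibition of growth and lower numbers for stronger inhibition of growth), compound 1 gives > 80000 nM which is a limit and not a number. Compound 2 stands at 754 nM as the only true number shown. Compound 3 `O=C(Nc1ccccc1C(F)(F)F)C1CCc2ccccc2N1C(=O)c1ccc(Cl)cc1` differs from compound 2 by 4-chlorophenyl in place of 3-chlorophenyl on a carbonyl carbon. Within the data shown here, the one measured step (an at least 100-fold lower number from compound 1 to compound 2 (2.02 log units; beyond the scatter)) was large, but it swapped ethyl for 3-chlorophenyl and does not test moving the chlorine. The estimated 1.1-fold higher number from compound 2 to compound 3 (0.03 log units; within the scatter) is expected to be modest, with no favoured direction. Compound 3 is expected at 800 nM with 250 nM to 2500 nM as the estimated range.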

Compound 3, concentration for 50% growth inhibition: 551 nM
Compound 3: the middle estimate sits 1.5-fold (0.16 log units) above what was measured, and the stated range covers the measured number.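

In this assay, moving the chlorine gives a 1.4-fold lower number from compound 2 to compound 3 (0.14 log units; within the scatter), so 3-chlorophenyl and 4-chlorophenyl on this carbonyl carbon cannot be told apart. With 4-chlorophenyl in place of ethyl the result is an at least 140-fold lower number from compound 1 to compound 3 (2.16 log units; beyond the scatter), so the large step seen with 3-chlorophenyl also holds for a second chlorophenyl. That step rests on a limit for compound 1, not on a number: the limit of > 80000 nM in this assay, at which 1 of the 3 values shown sits.

Still open, as far as these compounds go, is whether the chlorine is needed at all, and whether a plain phenyl, a pyridine or a cyclohexyl on this carbonyl carbon would give similar values.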